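This account rests on a few compounds, and the source may have more. Where it says the series, first, only, none or still open, it means among the compounds named here.

Compound 3 `COc1ccc2nccc(C3CN(C4CCN(Cc5cc6ccccc6s5)CC4)C(=O)O3)c2c1` is built on a shared core that carries a 1-benzothiophen-2-yl group on a saturated chain carbon bound to an amine nitrogen in a ring. In an in vitro functional assay on RBL cells for antagonist activity at C-C chemokine receptor type 8 (Homo sapiens), read by FLIPR and calcium flux (a lower number here means a stronger inhibitor, a higher number a weaker inhibitor), compound 3 gives 794 nM, the lowest of the two numbers shown. Compound 2 `COc1ccc2nccc(C3CN(C4CCN(Cc5cc6ccccc6o5)CC4)C(=O)O3)c2c1` gives 1260 nM in this assay, and the step of a 1.6-fold lower number from compound 2 to compound 3 (0.20 log units; within the scatter) lies within the scatter. For compound 1 `COc1ccc2nccc(C3CN(C4CCN(Cc5c[nH]c6ccccc56)CC4)C(=O)O3)c2c1` this assay reports only a limit, < 50200 nM. Compound 4 `CCCCCCN1CCC(N2CC(c3ccnc4ccc(OC)cc34)OC2=O)CC1` differs from compound 3 by pentyl in place of 1-benzothiophen-2-yl on a saturated chain carbon bound to an amine nitrogen in a ring. Within the data shown here, no measured step exchanges an aromatic bicycle for an open chain, so none bears directly on this change. Compound 4 is therefore expected to be a weaker inhibitor, around 5000 nM (range 1000 nM to 25000 nM). That expectation means a step of a 6.3-fold higher number from compound 3 to compound 4 (0.80 log units; beyond the scatter).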

Compound 4, half-maximal inhibitory concentration: 501 nM
The estimate for compound 4 lay 10-fold (1.00 log units) above the measured number; the measured number lies below the stated range.
By their numbers in this assay, from the lowest: compounds 4, 3 and 2 (each within the scatter of the next, the first and the last beyond it).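

At this position, on a saturated chain carbon bound to an amine nitrogen in a ring, an aromatic ring system is not required for activity among the compounds with readable numbers. Pentyl, with no ring and no hydrogen-bond acceptor, gives a 1.6-fold lower number from compound 3 to compound 4 (0.20 log units; within the scatter) and a 2.5-fold lower number from compound 2 to compound 4 (0.40 log units; beyond the scatter) against the two ring-bearing groups.

From the compounds shown here alone, whether a longer chain, or a chain ending in an amine or a carboxylic acid, would keep this level remains open. Compound 1 has only a limit, so the steps involving it cannot be read: the limit of < 50200 nM in this assay, at which 1 of the 4 values shown sits.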